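Para-substituent swap on the aryl amide: fluoro to trifluoromethyl

A few compounds are considered here, and "the series" means these few. Any claim that something is new, unique, unknown or untested is made for them only; others in the source may bear on it.

Measured so far:
compound 1 `COc1cc2c(Oc3ccc(NC(=O)c4cc(-c5ccc(F)cc5)ccn4)cc3F)ccnc2cc1OCCCN1CCCCC1` — 12500 nM
compound 2 `COc1cc2c(Oc3ccc(NC(=O)c4cc(-c5ccccc5F)ccn4)cc3F)ccnc2cc1OCCCN1CCCCC1` — "not determined" (no result reported)

Notes on the series. In a functional assay on U-87MG ATCC cells (Homo sapiens) for cytotoxicity, read by MTT assay, with a stated time of 72 h (a lower number here means a stronger inhibitor, a higher number a weaker inhibitor), compound 1 gives 12500 nM. For the measured compounds named here, this is the only number available; compound 2 carries "not determined" (no result reported), so nothing can be said about how the two compare, and no step between measured compounds exists to calibrate the next change.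

Compound 3 `COc1cc2c(Oc3ccc(NC(=O)c4cc(-c5ccc(C(F)(F)F)cc5)ccn4)cc3F)ccnc2cc1OCCCN1CCCCC1` is the next entry for this assay. Relative to compound 1 it differs by trifluoromethyl in place of fluoro on an aromatic carbon. The change is small and confined to the distal aryl ring of the amide; the shared core and the side chain are untouched.

Going by the values given here, with no measured step to lean on, the expectation is a modest shift from compound 1 to compound 3, perhaps toward a somewhat stronger inhibitor but not clearly beyond the scatter. The expected step is a 1.8-fold lower number from compound 1 to compound 3 (0.25 log units; within the scatter). On that basis compound 3 is estimated at 7000 nM, with a range from 2000 nM to 22000 nM, in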

Compound 3, half-maximal inhibitory concentration: 1630 nM
Estimate against measurement, compound 3: 4.3-fold (0.63 log units) above; the measured number lies below the stated range.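

In this assay, for the compounds shown here, the group on this aromatic carbon proves able to move the number: trifluoromethyl in place of fluoro gives a 7.7-fold lower number from compound 1 to compound 3 (0.88 log units; beyond the scatter), the first measured step and one that lies beyond the scatter. A single change para to a large group, with the shared core and the side chain held fixed, is therefore enough to shift this assay toward a stronger inhibitor, which the lone value available earlier could not show. No measurement is at hand that bears on what lies behind this step.

One pair cannot tell whether the step is particular to trifluoromethyl or would be shared by other groups on the same carbon, and a nitrile, a methoxy group, an amine or a carboxylic acid there would each bear on that question. Going by these compounds, it also remains open whether a step of this size would recur on a different side chain in place of the piperidine-bearing propoxy chain, since every comparison so far rests on that one chain and the shared core.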